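Replacing the piperazinium head of compound 2 with an ethylpyrrolidinium

The source may hold more compounds than are shown below. What is called first, only, known or untested is meant among the compounds shown, and "the series" means these compounds.

Compound 2 `CN1CC[N+](C)(CCCCCCCOc2ccc(-n3cc(C(=O)Nc4cc(F)cc(F)c4)c(=O)c4ccc(N(C)C)nc43)cc2Cl)CC1` holds the higher of the two results in an assay on LX2 cells for inhibition of COL1A1 promoter (Homo sapiens), read by a luciferase reporter, with a stated time of 24 h, tested at 50 uM; a higher number here means a stronger effect of the compound at the concentration tested, a lower number a weaker effect: compound 2 gives 15.4%, whereas compound 1 `CN(C)c1ccc2c(=O)c(C(=O)Nc3cc(F)cc(F)c3)cn(-c3ccc(OCCCCCCC[N+]4(C)CCCC4)c(Cl)c3)c2n1` gives 2.59%. Among the compounds with values here, the single measured step, a number 12.8 percentage points higher from compound 1 to compound 2 (beyond the scatter), bears directly on the next change. Compound 3 `CC[N+]1(CCCCCCCOc2ccc(-n3cc(C(=O)Nc4cc(F)cc(F)c4)c(=O)c4ccc(N(C)C)nc43)cc2Cl)CCCC1` differs from compound 2 by a group of 7 heavy atoms (6 carbon, 1 nitrogen; one five-membered non-aromatic ring with 1 hetero atom) in place of a group of 8 heavy atoms (6 carbon, 2 nitrogen; one six-membered non-aromatic ring with 2 hetero atoms), on a saturated chain carbon, seven bonds along the chain from an oxygen on an aromatic ring, which largely undoes that step, leaving a five-membered ring as in compound 1. Compound 3 is therefore expected to fall back toward compound 1, a step of a number 10.4 percentage points lower from compound 2 to compound 3 (beyond the scatter) in this assay. The estimate for compound 3 is 5%, within -5% to 15%.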

Compound 3, a percentage reported as inhibition, at one concentration (the size of the read-out at that concentration, not a potency): 23.5%
Beside the measured number, compound 3's estimate is 18.5 percentage points below it; the measured number lies above the stated range.
By their numbers in this assay, from the lowest: compound 1; then compounds 2 and 3 (each within the scatter of the next).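

In this assay, the five-membered ring alone does not keep the number low: methyl in place of hydrogen on the saturated chain carbon bound to the amine nitrogen in the ring gives a number 20.9 percentage points higher from compound 1 to compound 3 (beyond the scatter). The change of ring, a number 8.1 percentage points higher from compound 2 to compound 3 (within the scatter), leaves the six-membered head with two hetero atoms and the five-membered head carrying the added methyl unordered. No measurement offered here explains either step. The compounds shown leave open whether a propyl group at this place would carry the number further, and whether a piperidinium head would behave like the five-membered ring.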